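Aryl tail change: hydroxyphenyl to dimethoxyphenyl

A few compounds are considered here, and "the series" means these few. Any claim that something is new, unique, unknown or untested is made for them only; others in the source may bear on it.

Measured so far, in an assay on HEK293 cells for displacement of a labelled ligand from Melanocortin receptor 4 (Homo sapiens); a higher number here means a weaker inhibitor, a lower number a stronger inhibitor:
- compound 1 `CC[C@H](C)C(N)c1cc(C(F)(F)F)ccc1N1CCN(C(=O)CCc2ccc(Cl)cc2Cl)CC1`: 75 nM
- compound 2 `CC(C)C[C@H](N)c1cc(C(F)(F)F)ccc1N1CCN(C(=O)CCc2ccccc2O)CC1`: 3300 nM
- compound 3 `CC(C)C[C@H](N)c1cc(C(F)(F)F)ccc1N1CCN(C(=O)CCc2ccc(O)cc2)CC1`: for compound 3 this assay gives only a limit, > 10000 nM 

Compound 3 therefore stands at the weak end of the three; the value of compound 3 is a limit of this assay and not a number (the limit of > 10000 nM in this assay, at which 1 of the 3 values shown sits). Compound 1 and compound 2 differ in two places, so their values can only be set side by side: compound 1 gives 75 nM and compound 2 gives 3300 nM.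

Compound 4 `COc1ccc(OC)c(CCC(=O)N2CCN(c3ccc(C(F)(F)F)cc3[C@@H](N)CC(C)C)CC2)c1` carries 2,5-dimethoxyphenyl in place of 4-hydroxyphenyl on a saturated chain carbon, two bonds along the chain from a carbonyl carbon. Among the measured compounds shown here, the one measured step that bears on this is an at least 3.0-fold higher number from compound 2 to compound 3 (0.48 log units; beyond the scatter), which shows that moving the hydroxyl from the 2-position to the 4-position of the aryl tail costs potency in this assay. For the measured compounds named here, compound 4 removes the 4-hydroxyl and places a methoxy at the 2-position, so a return toward the level of compound 2 is expected, with no measured step covering the second methoxy.

For compound 4 in this assay the estimate is 2000 nM, with a range from 500 nM to 8000 nM. This means an expected step of an at least 5.0-fold lower number from compound 3 to compound 4 (0.69 log units; beyond the scatter).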

Compound 4, inhibition constant: 2500 nM
Beside the measured number, compound 4's estimate is 1.3-fold (0.10 log units) below it, and the stated range covers the measured number.
By their numbers in this assay, from the lowest: compound 1; then compounds 4 and 2 (each within the scatter of the next). At a limit, above all of these: compound 3.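

In this assay the 2,5-dimethoxyphenyl tail, on a saturated chain carbon, two bonds along the chain from a carbonyl carbon, gives an at least 4.0-fold lower number from compound 3 to compound 4 (0.60 log units; beyond the scatter) against the 4-hydroxyphenyl tail, so this position is not closed to a larger tail with 0 hydrogen-bond donors. Compound 3 stands at a limit and not at a number, so the size of this step is only a lower bound: the limit of > 10000 nM in this assay, at which 1 of the 4 values shown sits. Against the 2-hydroxyphenyl tail the change gives a 1.3-fold lower number from compound 2 to compound 4 (0.12 log units; within the scatter), which leaves the two tails indistinguishable in this assay and shows that a hydroxyl is not required on this tail to reach this level.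

The compounds shown do not separate the two methoxy groups, and a tail with a single methoxy group would be needed to tell which of them accounts for the step from compound 3. On these data alone, compound 1 gives 75 nM with a chlorine-bearing tail and a different side chain on the amine-bearing carbon, so whether that tail alone would improve on compound 4 stays open.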